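The source may report more compounds than this note shows. Statements on the series, on what has been measured and on what is new or still open speak of the compounds shown alone.

Of the compounds shown here, three sharing a common core have been measured in an assay on tissue (RPTEC cells) for inhibition of solute carrier family 22 member 12 (Homo sapiens), read by scintillation counting, with stated times of 15 min and 2 h; a higher number here means a weaker inhibitor, a lower number a stronger inhibitor. Compound 1 `Cc1c(C)n(C(=O)c2ccc(O)c(C#N)c2)c2ccccc12` gives 10800 nM, compound 2 `N#Cc1cc(C(=O)N2CCc3ccccc32)cc(C#N)c1O` gives 83900 nM, and compound 3 `N#Cc1cc(C(=O)N2CCc3ccccc32)cc(C2CC2)c1O` gives 8800 nM. Compound 2 stands highest of the three numbers: compound 1 sits nearest to it and compound 3 furthest, the latter gap being beyond the scatter. The compound still to be tested, compound 4 `N#Cc1cc(C(=O)N2CCc3ccccc32)cc(Cl)c1O`, differs from compound 2 by chloro in place of cyano on an aromatic carbon. Within the data shown here, only one measured step bears on this change, namely a 9.5-fold lower number from compound 2 to compound 3 (0.98 log units; beyond the scatter), in which a different group entered at the same place on the same ring. With chloro entering rather than cyclopropyl, a step in the same direction in this assay is expected, though not necessarily of the full size seen with cyclopropyl. For compound 4 the expected step is a 4.2-fold lower number from compound 2 to compound 4 (0.62 log units; beyond the scatter). For compound 4 the estimated value in this assay is therefore 20000 nM, within a range from 6000 nM to 60000 nM.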

Compound 4, half-maximal inhibitory concentration: 14700 nM
The estimate for compound 4 lay 1.4-fold (0.13 log units) above the measured number; the measured number falls inside the stated range.
By their numbers in this assay, from the lowest: compounds 3, 1 and 4 (each within the scatter of the next); then compound 2.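

In this assay, chloro in place of cyano on this aromatic carbon, ortho to a hydroxy group, gives a 5.7-fold lower number from compound 2 to compound 4 (0.76 log units; beyond the scatter), which is beyond the scatter, so the lower number no longer rests on cyclopropyl alone. The two replacements cannot be told apart at this place, since a 1.7-fold higher number from compound 3 to compound 4 (0.22 log units; within the scatter) lies within the scatter, although chloro brings one heavy atom and no ring. No measurement at hand accounts for the gap between cyano and either replacement.

The compounds shown leave open whether an amine, a methoxy group or a carboxylic acid at this place would give a number close to those of compound 3 and compound 4, or one closer to that of compound 2. They also leave open whether a fluoro or bromo group would behave as chloro does.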